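Amino in place of methylcarbamoyl: expectation for compound 4

The source may hold more compounds than are shown below. What is called first, only, known or untested is meant among the compounds shown, and "the series" means these compounds.

Three compounds on one shared core have been run in an assay for inhibition of Indoleamine 2,3-dioxygenase 1 (Homo sapiens), with stated times of 10 min and 60 min, tested at 10 uM; on this read-out higher numbers stand for a stronger effect at the one concentration tested and lower numbers for a weaker effect. Compound 1 `FC(F)(F)c1cc(NC[C@H]2CCCN2)c2cn[nH]c2c1` gives 34%. Compound 2 `FC(F)(F)c1cc(NCC2CNC2)c2cn[nH]c2c1` gives 10%. Compound 3 `CNC(=O)c1cccc(CNc2cc(C(F)(F)F)cc3[nH]ncc23)c1` gives 33%. On these numbers compound 3 stands second highest of the three: its value lies within the scatter of that of compound 1 and beyond the scatter above that of compound 2.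

Within the data shown here, the only step recorded between measured compounds is a number 24 percentage points lower from compound 1 to compound 2 (beyond the scatter). That step concerns a ring swap on a saturated chain carbon bound to a nitrogen on an aromatic ring, a different part of the molecule from the one altered below, so it offers no direct guide to the change in compound 4.

Among the measured compounds shown here, compound 4 `Nc1cccc(CNc2cc(C(F)(F)F)cc3[nH]ncc23)c1` is the next compound for this assay. amino in place of methylcarbamoyl on an aromatic carbon No measured step addresses an exchange of this kind on this aromatic carbon, so the size of the step cannot be anchored in the data. As a working guess, a modest loss is assumed and the step is expected to be a number 9 percentage points lower from compound 3 to compound 4 (within the scatter), with a wide range to reflect the lack of a precedent. For compound 4 the estimated value in this assay is 24%, expected to fall between 6% and 42%.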

Compound 4, a percentage reported as inhibition, at one concentration (the size of the read-out at that concentration, not a potency): 24%
Beside the measured number, compound 4's estimate shows no gap at the digits printed; the measured number falls inside the stated range.
By their numbers in this assay, from the lowest: compound 2; then compounds 4, 3 and 1 (each within the scatter of the next).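

In this assay, amino in place of methylcarbamoyl on this aromatic carbon gives a number 9 percentage points lower from compound 3 to compound 4 (within the scatter), so on this read-out at the one concentration tested, the methylcarbamoyl group with its carbonyl cannot be told apart from the much smaller amino group. Reading the same compound against the saturated-chain variants, 3-aminophenyl in place of azetidin-3-yl gives a number 14 percentage points higher from compound 2 to compound 4 (beyond the scatter), while 3-aminophenyl in place of pyrrolidin-2-yl gives a number 10 percentage points lower from compound 1 to compound 4 (within the scatter), which separates this aryl group from azetidin-3-yl but not from pyrrolidin-2-yl. The data at hand offer no account of any of these steps.

Open, going by these compounds, is whether a carboxylic acid or a hydroxyl group on this aromatic carbon would stay within the scatter of compound 3 and compound 4 or drop towards the level of compound 2 at 10% in this assay. Also open, on these data alone, is whether a longer chain in place of the single saturated chain carbon would change the read-out, and whether the stronger and weaker effects seen at this one concentration would keep their order at other concentrations.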